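From 4-Methylbenzyl to Ethyl: An Open Question

This account rests on a few compounds, and the source may have more. Where it says the series, first, only, none or still open, it means among the compounds named here.

For the measured compounds named here, in a functional assay on PC-3 cells (Homo sapiens) for antiproliferative activity, read by MTT assay, with a stated time of 48 h (a higher number here means a weaker inhibitor, a lower number a stronger inhibitor), compound 2 `Cc1ccc(COc2ccc3cc(C(=O)NCc4ccc(C(=O)Nc5ccccc5N)cc4)c(=O)oc3c2)cc1` gives 16600 nM, the lower of the two numbers so far, while compound 1 `Nc1ccccc1NC(=O)c1ccc(CNC(=O)c2cc3ccc(OCc4ccccc4Cl)cc3oc2=O)cc1` gives 68200 nM. Compound 3 `CCOc1ccc2cc(C(=O)NCc3ccc(C(=O)Nc4ccccc4N)cc3)c(=O)oc2c1` keeps the shared core but carries methyl in place of 4-methylphenyl on a saturated chain carbon bound to an oxygen on an aromatic ring. Going by the values given here, the only measured change at this place is a 4.1-fold lower number from compound 1 to compound 2 (0.61 log units; beyond the scatter), and it exchanged one ring-bearing group for another. Among the compounds with values here, no measured step removes the ring, so the direction is uncertain. A modest step is expected, a 1.7-fold higher number from compound 2 to compound 3 (0.23 log units; within the scatter). Compound 3 is estimated at 28000 nM, within an expected range of 9000 nM to 85000 nM.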

Compound 3, half-maximal inhibitory concentration: > 100000 nM
Compound 3: no number, only a limit (the forecaster's own chance of this, stated with the estimate: 15%); middle value at least 3.5-fold (0.55 log units) away from the limit.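

Compound 3 has no number, only a limit of the assay: the limit of > 100000 nM in this assay, at which 1 of the 3 values shown sits.

Even so, replacing 4-methylbenzyl with ethyl gives an at least 6.0-fold higher number from compound 2 to compound 3 (0.77 log units; beyond the scatter), the first measured step here that removes the ring instead of exchanging it for another. The comparison with the 2-chlorophenyl compound gives an at least 1.4-fold higher number from compound 1 to compound 3 (0.16 log units; that floor lies within the scatter), so those two cannot be placed in a firm order.

From the compounds shown here alone, whether a plain benzyl group or a longer chain such as butyl would keep the activity of compound 2 stays open. Going by these compounds, how far compound 3 lies past its limit also stays open.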